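The source may hold more compounds than are shown below. What is called first, only, known or untested is meant among the compounds shown, and "the series" means these compounds.

In an ADME assay on CCRF-CEM cells (Homo sapiens) for inhibition, read by fluorescence and resazurin assay, with a stated time of 72 h (a lower number here means a stronger inhibitor of growth, a higher number a weaker inhibitor of growth), the three measured compounds give:
Compound 1 `N[C@H]1CC[C@H](Nc2nc(Nc3ccc(-c4ccoc4)nc3)c3ncn(C4CCCC4)c3n2)CC1` gives 619 nM.
Compound 2 `COc1ccccc1-c1ccc(Nc2nc(N[C@H]3CC[C@H](N)CC3)nc3c2ncn3C2CCCC2)cn1` gives 460 nM.
Compound 3 `N[C@H]1CC[C@H](Nc2nc(Nc3ccc(-c4ccccc4O)nc3)c3ncn(C4CCCC4)c3n2)CC1` gives 617 nM.

Compound 3 sits close to both of its neighbours: the difference from compound 1 is a 1.0-fold lower number from compound 1 to compound 3 (0.00 log units; within the scatter), and that from compound 2 is a 1.3-fold higher number from compound 2 to compound 3 (0.13 log units; within the scatter). Compound 4 `COc1ccc(-c2ccc(Nc3nc(N[C@H]4CC[C@H](N)CC4)nc4c3ncn4C3CCCC3)cn2)cc1` differs from compound 3 by 4-methoxyphenyl in place of 2-hydroxyphenyl on an aromatic carbon. Among the measured compounds shown here, the steps that bear on this all swap the group at the same place: a 1.3-fold lower number from compound 1 to compound 2 (0.13 log units; within the scatter), a 1.0-fold lower number from compound 1 to compound 3 (0.00 log units; within the scatter) and a 1.3-fold higher number from compound 2 to compound 3 (0.13 log units; within the scatter). Every one of them stays within the scatter, so no step beyond the scatter is expected here either, with a 1.2-fold lower number from compound 3 to compound 4 (0.07 log units; within the scatter). Compound 4 is therefore estimated at 520 nM, with a range from 250 nM to 1100 nM.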

Compound 4, concentration for 50% growth inhibition: 544 nM
The estimate for compound 4 lay 1.0-fold (0.02 log units) below the measured number; measured number inside the range.
By their numbers in this assay, from the lowest: compounds 2, 4, 3 and 1 (each within the scatter of the next).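

In this assay, 4-methoxyphenyl at this position cannot be told apart from the other groups: a 1.1-fold lower number from compound 3 to compound 4 (0.05 log units; within the scatter), a 1.2-fold higher number from compound 2 to compound 4 (0.07 log units; within the scatter) and a 1.1-fold lower number from compound 1 to compound 4 (0.06 log units; within the scatter). The second of these steps is new in kind, since it shows that moving the methoxy group around the phenyl ring, from 2-methoxyphenyl to 4-methoxyphenyl, also stays within the scatter. Nothing available explains this flat result. Every group shown here is an aromatic ring, so it remains open whether an amine, a carboxylic acid or a longer chain at this position would give a step beyond the scatter.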